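This account rests on a few compounds, and the source may have more. Where it says the series, first, only, none or still open, it means among the compounds named here.

Measured so far in a physicochemical assay for solubility, using the shake flask method, in simulated intestinal fluid, measured as kinetic solubility, with a stated time of 2 h, at 25 degrees C, at pH 6.5; a higher number here means a more soluble compound, a lower number a less soluble compound: compound 1 `Cc1nc(C(N)=O)c(N)c2c1C(=O)N(Cc1ccccc1)C2=O` gives < 5000 nM, a limit of the assay rather than a number. Compound 2 `Cc1nc(-c2nc(C(F)(F)F)no2)c(N)c2c1C(=O)N(Cc1ccccc1)C2=O` gives < 5000 nM, again only a limit. Compound 3 `Cc1noc(-c2nc(C)c3c(c2N)C(=O)N(Cc2ccc(OC(F)(F)F)cc2)C3=O)n1` gives < 5000 nM, likewise a limit.

Going by the values given here, all three compounds therefore sit at the same place, (the limit of < 5000 nM in this assay, at which 3 of the 3 values shown sit), and the one step between measured compounds, a step that the two limits leave unreadable from compound 1 to compound 2, cannot be read from the two limits. As far as these compounds go, compound 3 stands with only a limit against its name, and the two other values shown are limits as well, so its position on a true scale is unknown.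

Compound 4 `Cc1noc(-c2nc(C)c3c(c2N)C(=O)N(Cc2ccc(C#N)cc2)C3=O)n1` differs from compound 3 in one place: cyano in place of trifluoromethoxy on an aromatic carbon. Among the compounds with values here, no measured step touches either the group that leaves or the group that enters, and the single measured step is unreadable, so no size or direction can be derived from the data; the account can only expect that compound 4 stays in the same region as the limits seen. Compound 4 is therefore estimated at 3000 nM, with a range from 500 nM to 9000 nM. The step from compound 3 to compound 4 implied by that estimate, a step that the limit leaves unreadable from compound 3 to compound 4, is expected to be none beyond the scatter.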

Compound 4, solubility: < 5000 nM
Compound 4: a limit, no number; the forecaster's own chance of this, stated with the estimate: 65%; the middle value does not contradict the limit.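

Compound 4, like compound 3, carries only a limit, so the step between them, cyano in place of trifluoromethoxy, cannot be read: the limit of < 5000 nM in this assay, at which 4 of the 4 values shown sit.

The compounds shown leave open where any of them truly stands in this assay, and whether any of these group changes moves the value at all.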